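Removing the aryl cap from a triphosphate uridine oxime

This account rests on a few compounds, and the source may have more. Where it says the series, first, only, none or still open, it means among the compounds named here.

Compound 1 `O=c1[nH]/c(=N\OCCCc2cccc([N+](=O)[O-])c2)ccn1[C@@H]1O[C@H](COP(=O)(O)OP(=O)(O)OP(=O)(O)O)[C@@H](O)[C@H]1O` in a functional assay on 1321-N1 cells for agonist activity at P2Y purinoceptor 6 (Homo sapiens), read by scintillation counting and inositol phosphate accumulation (a higher number here means that more compound is needed for the effect, a lower number that less compound is needed), gives 9700 nM. Compound 2 `O=c1[nH]/c(=N\OCCCc2ccncc2)ccn1[C@@H]1O[C@H](COP(=O)(O)OP(=O)(O)OP(=O)(O)O)[C@@H](O)[C@H]1O` gives 4280 nM, the lowest of the two numbers, with a 2.3-fold lower number from compound 1 to compound 2 (0.36 log units; beyond the scatter). Compound 3 `C#CCCCO/N=c1/ccn([C@@H]2O[C@H](COP(=O)(O)OP(=O)(O)OP(=O)(O)O)[C@@H](O)[C@H]2O)c(=O)[nH]1` carries ethynyl in place of pyridin-4-yl on a saturated chain carbon, three bonds along the chain from an oxygen. For the measured compounds named here, the only measured step swaps one six-membered aromatic ring for another, whereas here the ring is removed entirely, so it bears on this change only loosely. Compound 3 is therefore expected to shift by a 1.4-fold higher number from compound 2 to compound 3 (0.15 log units; within the scatter) in this assay, a small rise in the number. The estimate for compound 3 is 6000 nM, between 2000 nM and 18000 nM.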

Compound 3, half-maximal effective concentration: 3000 nM
For compound 3 the middle estimate is 2.0-fold (0.30 log units) above the measured one; low and high end bracket the measured number.
By their numbers in this assay, from the lowest: compounds 3 and 2 (each within the scatter of the next); then compound 1.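

In this assay, the ring at the end of the chain is not needed to hold the number: replacing pyridin-4-yl with ethynyl gives a 1.4-fold lower number from compound 2 to compound 3 (0.15 log units; within the scatter) and so no real change. Against 3-nitrophenyl the same group gives a 3.2-fold lower number from compound 1 to compound 3 (0.51 log units; beyond the scatter) and a clear gain, so a ring-free group of 2 heavy atoms serves at this position. As far as these compounds go, whether an amine, a carboxylic acid or a chain longer than pent-4-yn-1-yl would serve as well remains open. No measured evidence explains these numbers.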